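Ester Side-Chain Exchange on Compound 2, Estimated Ahead

This account rests on a few compounds, and the source may have more. Where it says the series, first, only, none or still open, it means among the compounds named here.

For the measured compounds named here, compound 2 `COC(=O)C1=C(C)NC(C)=C(C(=O)OCCc2ccc(Cl)cc2)C1c1cccc([N+](=O)[O-])c1` holds the lower of the two numbers so far in a functional assay on HEK293 cells for antagonist activity at Voltage-dependent L-type calcium channel subunit alpha-1D (Rattus norvegicus), read by FLIPR (a lower number here means a stronger inhibitor, a higher number a weaker inhibitor), where compound 2 gives 39 nM; its only neighbour is compound 1 `C=C(C)CCOC(=O)C1=C(C)NC(C)=C(C(=O)OC)C1c1cccc([N+](=O)[O-])c1`, which in this assay gives 47 nM, a gap that sits within the scatter. Compound 3 `COC(=O)C1=C(C)NC(C)=C(C(=O)OCCC(C)c2ccccc2)C1c1cccc([N+](=O)[O-])c1` differs from compound 2 by 1-phenylethyl in place of 4-chlorophenyl on a saturated chain carbon, two bonds along the chain from an oxygen next to a carbonyl group, at the saturated chain carbon two bonds along the chain from the oxygen next to the carbonyl group. Going by the values given here, the single measured step that bears on this place, a 1.2-fold lower number from compound 1 to compound 2 (0.08 log units; within the scatter), exchanged one group for another at the same chain carbon and moved the number hardly at all. Among the compounds with values here, with only that step to go on, the exchange in compound 3 is expected to leave this assay essentially where it was, that is a 1.1-fold higher number from compound 2 to compound 3 (0.03 log units; within the scatter), with no shift beyond the scatter. Compound 3 is therefore estimated at 42 nM, within the range 15 nM to 120 nM.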

Compound 3, half-maximal inhibitory concentration: 11 nM
Compound 3: the middle estimate sits 3.8-fold (0.58 log units) above what was measured; measured number below the stated range.
By their numbers in this assay, from the lowest: compound 3; then compounds 2 and 1 (each within the scatter of the next).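

In this assay, the saturated chain carbon, two bonds along the chain from an oxygen next to a carbonyl group, turned out to be sensitive to the group it carries: 1-phenylethyl in place of 4-chlorophenyl gives a 3.5-fold lower number from compound 2 to compound 3 (0.55 log units; beyond the scatter) and 1-phenylethyl in place of 1-methylethenyl gives a 4.3-fold lower number from compound 1 to compound 3 (0.63 log units; beyond the scatter) as the counterpart. Both steps lie beyond the scatter, so the flat step between compound 1 and compound 2 did not hold for every exchange here. Nothing shown here accounts for this gain.

The compounds shown leave open whether the lower number goes with the extra methyl branch, the extra chain carbon or the missing chlorine, all of which change together in compound 3. On these data alone, whether 3-phenylpropyl or an amine at this carbon would keep the gain also stays open.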